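Swapping chloro for methoxy on a cytotoxic series

The source may hold more compounds than are shown below. What is called first, only, known or untested is meant among the compounds shown, and "the series" means these compounds.

compound 1 `Cc1ccc2c(O)nc(-c3ccccc3C)cc2c1`: 5890 nM
compound 2 `Cc1ccc(-c2cc3cc(C)ccc3c(N3CCN(C)CC3)n2)cc1`: 7240 nM
compound 3 `CN1CCN(c2nc(-c3ccc(Cl)cc3)cc3c(N(C)C)cccc23)CC1`: 7450 nM

In a functional assay on A549 cells (Homo sapiens) for cytotoxicity, read by sulforhodamine B assay (a higher number here means a weaker inhibitor, a lower number a stronger inhibitor), compound 3 gives 7450 nM, a value within the usual scatter of both compound 2 and compound 1. All three measured compounds therefore cannot be told apart on this read-out, even though their structures differ in more than one place. Going by the values given here, no measured pair differs by a single change, so no direct precedent exists for the next step.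

The unmeasured compound 4 `COc1ccc(-c2cc3c(N(C)C)cccc3c(N3CCN(C)CC3)n2)cc1` keeps the structure of compound 3 except for one group: methoxy in place of chloro on an aromatic carbon. This turns 4-chlorophenyl into 4-methoxyphenyl, para to a large group. With so little evidence, the expectation is no change beyond the scatter in this assay, in either direction. The expected step of a 1.1-fold lower number from compound 3 to compound 4 (0.03 log units; within the scatter) is an estimate resting only on how closely the three measured values agree. For compound 4 the estimated value is 7000 nM, with an expected range of 3000 nM to 15000 nM.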

Compound 4, half-maximal inhibitory concentration: 1820 nM
For compound 4 the middle estimate is 3.8-fold (0.59 log units) above the measured one; measured number below the stated range.
By their numbers in this assay, from the lowest: compound 4; then compounds 1, 2 and 3 (each within the scatter of the next).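

Replacing chloro with methoxy on an aromatic carbon, para to a large group, gives a 4.1-fold lower number from compound 3 to compound 4 (0.61 log units; beyond the scatter) in this assay. Going by these compounds alone, this is the first comparison that changes only one place, and it shows that the number responds to what this position carries, a response the earlier compounds could not reveal because they differ from one another in more than one place. Nothing available here explains the change from 4-chlorophenyl to 4-methoxyphenyl.

Within the data shown here, with only one group swapped at this position, it remains open whether the effect is specific to methoxy or would also appear with an amine, a hydroxyl or a longer ether such as ethoxy. From the compounds shown here alone, it also remains open whether the same swap would act similarly on the differently substituted core of compound 2.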